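Lengthening a hydroxycarbamoyl chain from an assay limit

A few compounds are considered here, and "the series" means these few. Any claim that something is new, unique, unknown or untested is made for them only; others in the source may bear on it.

Measured in a functional assay on PC-3 cells (Homo sapiens) for antiproliferative activity, read by sulforhodamine B assay, with a stated time of 48 h; on this read-out lower numbers stand for stronger inhibition of growth and higher numbers for weaker inhibition of growth:
Compound 1 (`CC(C)CCc1c(OCCCCCC(=O)NO)ccc2c1OC(=O)CC2`): > 30000 nM (a limit)
Compound 2 (`CC(C)CCc1c(OCCCCC(=O)NO)ccc2c1OC(=O)CC2`): > 30000 nM (a limit)

Compound 2 has no exact number, only a limit, and it shares this with compound 1, as the limit of > 30000 nM in this assay, at which 2 of the 2 values shown sit, records. Compound 3 (`CC(C)CCc1c(OCCCCCCCC(=O)NO)ccc2c1OC(=O)CC2`) differs from compound 2 by 3-(hydroxycarbamoyl)propyl in place of hydroxycarbamoyl on a saturated chain carbon, four bonds along the chain from an oxygen on an aromatic ring and places 3-(hydroxycarbamoyl)propyl where hydroxycarbamoyl stood. Within the data shown here, the one measured step (a step that the two limits leave unreadable from compound 1 to compound 2) gives no usable size or direction. Only a small step toward stronger inhibition is therefore expected (an at least 1.2-fold lower number from compound 2 to compound 3 (0.07 log units; that floor lies within the scatter)). The estimate for compound 3 is 25000 nM with an expected range of 8000 nM to 60000 nM and another limit is quite possible.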

Compound 3, concentration for 50% growth inhibition: > 30000 nM
Compound 3 was reported as a limit; the forecaster's own chance of this, stated with the estimate: 60%; middle value at least 1.2-fold (0.07 log units) from the limit.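

No step among compound 1, compound 2 and compound 3 can be read, as all three share one limit: the limit of > 30000 nM in this assay, at which 3 of the 3 values shown sit.

Left open is how strongly each compound inhibits growth, and whether chain length makes any difference.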